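The source may hold more compounds than are shown below. What is called first, only, known or untested is meant among the compounds shown, and "the series" means these compounds.

Of the compounds shown here, three that share one core have been measured in a functional assay on CHO cells with adenosine receptor A1 (Homo sapiens) as the target, read by cAMP accumulation and immunoassay, with a stated time of 6 min, tested at 0.1 uM; on this read-out lower numbers stand for a stronger effect and higher numbers for a weaker effect at the one concentration tested. Compound 1 `CC(C)N1CCN(Cc2csc(N)c2C(=O)c2ccc(Cl)cc2)CC1` gives 3.6%, compound 2 `Nc1scc(CN2CCN(c3ccc([N+](=O)[O-])cc3)CC2)c1C(=O)c1ccc(Cl)cc1` gives -13%, and compound 3 `Nc1scc(CN2CCN(c3cccc(F)c3)CC2)c1C(=O)c1ccc(Cl)cc1` gives -37%. Compound 3 stands lowest of the three, with compound 2 nearest and compound 1 furthest. Every measured step alters the group on the amine nitrogen in the ring: a number 16.6 percentage points lower from compound 1 to compound 2 (beyond the scatter), a number 40.6 percentage points lower from compound 1 to compound 3 (beyond the scatter) and a number 24 percentage points lower from compound 2 to compound 3 (beyond the scatter), so the two aryl groups on that nitrogen gave lower numbers than the isopropyl of compound 1.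

Compound 4 `Nc1scc(CN2CCN(CCCc3ccc(Cl)cc3)CC2)c1C(=O)c1ccc(Cl)cc1` differs from compound 3 at that same nitrogen: 3-(4-chlorophenyl)propyl in place of 3-fluorophenyl on an amine nitrogen in a ring. The incoming group is a chain carrying an aryl ring rather than an aryl ring attached directly, so the step of a number 40.6 percentage points lower from compound 1 to compound 3 (beyond the scatter), in reverse, is the nearest guide, with some weight on the aryl-bearing steps. Compound 4 is therefore expected to move back toward compound 1, with an estimated step of a number 27 percentage points higher from compound 3 to compound 4 (beyond the scatter). Compound 4 is estimated at -10%, in a range from -40% to 20%.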

Compound 4, a percentage reported as activity, at one concentration (the size of the read-out at that concentration, not a potency): -3%
The estimate for compound 4 lay 7 percentage points below the measured number; low and high end bracket the measured number.
By their numbers in this assay, from the lowest: compound 3; then compounds 2, 4 and 1 (each within the scatter of the next, the first and the last beyond it).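

Among these compounds, at the amine nitrogen in the ring, the earlier compounds left open whether any group bearing an aryl ring would give a low number in this assay; a number 34 percentage points higher from compound 3 to compound 4 (beyond the scatter) shows that 3-(4-chlorophenyl)propyl does not keep the number reached with 3-fluorophenyl. The two other new steps, a number 10 percentage points higher from compound 2 to compound 4 (within the scatter) and a number 6.6 percentage points lower from compound 1 to compound 4 (within the scatter), both lie within the scatter, so compound 4 cannot be separated from either compound 1 or compound 2, even though those two stand apart beyond the scatter, and an aryl ring in the incoming group does not by itself set the number. Nothing available explains this result.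

As far as these compounds go, this change alters the chain and the ring substituent together, so their separate shares remain open. A 4-chlorophenyl attached directly to that nitrogen, or a 3-(3-fluorophenyl)propyl, would divide them.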